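This account rests on a few compounds, and the source may have more. Where it says the series, first, only, none or still open, it means among the compounds named here.

Measured compounds:
- Compound 1 `CCCCC(NC(=O)C(C)Oc1ccc(Cl)cc1Cl)c1ccc(F)cc1`: > 100000 nM
- Compound 2 `CC(Oc1ccc(Cl)cc1Cl)C(=O)NC(c1ccc(F)cc1)C1CCC1`: > 100000 nM

In an ADME assay on CHO cells (Cricetulus griseus) for cytotoxicity, read by LDH release (on this read-out higher numbers stand for weaker inhibition and lower numbers for stronger inhibition), compound 2 gives > 100000 nM, which is a limit of the assay and not a number. Compound 1 gives > 100000 nM, likewise a limit. Among the compounds with values here, compound 2 therefore has no exact value, and neither does its only neighbour, as the evidence shows: the limit of > 100000 nM in this assay, at which 2 of the 2 values shown sit.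

Compound 3 `CC(Oc1ccc(Cl)cc1Cl)C(=O)NC(CO)c1ccc(F)cc1` carries hydroxymethyl in place of cyclobutyl on a saturated chain carbon bound to an amide-type nitrogen and an aromatic carbon. Within the data shown here, the one measured step at this place is a step that the two limits leave unreadable from compound 1 to compound 2. It gives no size to carry over, so no step beyond the usual scatter is expected in this assay, in either direction. The expected change is a number no higher from compound 2 to compound 3 (the limit leaves the size open). For compound 3 the estimate is 100000 nM, with an expected range from 40000 nM to 200000 nM.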

Compound 3, half-maximal inhibitory concentration: 18000 nM
For compound 3 the middle estimate is 5.6-fold (0.74 log units) above the measured one, outside the stated range (below it).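

In this assay, the place on a saturated chain carbon bound to an amide-type nitrogen and an aromatic carbon now shows a readable change: hydroxymethyl in place of cyclobutyl gives an at least 5.5-fold lower number from compound 2 to compound 3 (0.74 log units; beyond the scatter). Against the butyl group of the other earlier compound, the same result reads as hydroxy in place of propyl, with an at least 5.5-fold lower number from compound 1 to compound 3 (0.74 log units; beyond the scatter). Exchanging butyl for cyclobutyl had given no such reading, and both of those compounds stayed at the limit of the assay: the limit of > 100000 nM in this assay, at which 2 of the 3 values shown sit.

From the compounds shown here alone, both steps start from limits and not from numbers, so their full size stays open, as does whether the change follows the hydroxy group or the loss of the carbon ring. Going by these compounds, how an amine, a carboxylic acid or a methoxymethyl group at this place would read also remains open.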